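Moving a methoxy group: compound 3 to compound 4

The source may hold more compounds than are shown below. What is called first, only, known or untested is meant among the compounds shown, and "the series" means these compounds.

In a functional assay on A549 cells (Homo sapiens) for cytotoxicity, read by MTT assay, with a stated time of 72 h (a higher number here means a weaker inhibitor, a lower number a stronger inhibitor), compound 1 (`COc1cccc(/C=C2\CCC/C(=C\c3ccccc3Br)C2=O)c1OC`) gives > 20000 nM, which is a limit. Compound 2 (`COc1cccc(/C=C2\CCC/C(=C\c3cccc(Br)c3)C2=O)c1OC`) gives > 20000 nM, also a limit. Compound 3 (`COc1ccccc1/C=C1\CCC/C(=C\c2cccc(OC)c2OC)C1=O`) gives > 20000 nM, again a limit and not a number. The series therefore offers only (the limit of > 20000 nM in this assay, at which 3 of the 3 values shown sit).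

Compound 4 (`COc1cccc(/C=C2\CCC/C(=C\c3cccc(OC)c3OC)C2=O)c1`) has 3-methoxyphenyl in place of 2-methoxyphenyl on a double-bonded chain carbon bound to a double-bonded ring carbon.

Among the compounds with values here, the closest precedent is a step that the two limits leave unreadable from compound 1 to compound 2. The other two, a step that the two limits leave unreadable from compound 1 to compound 3 and a step that the two limits leave unreadable from compound 2 to compound 3, give no size either. No measured step sizes this change, so no direction can be assigned.

The expected outcome is a step that the limit leaves unreadable from compound 3 to compound 4, with no change beyond the scatter anticipated. For compound 4 the estimated value is 22000 nM, with an expected range of 10000 nM to 40000 nM.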

Compound 4, half-maximal inhibitory concentration: 16400 nM
For compound 4 the middle estimate is 1.3-fold (0.13 log units) above the measured one, and the stated range covers the measured number.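

Only compound 4 reads as a number in this assay; the others stay at a limit: the limit of > 20000 nM in this assay, at which 3 of the 4 values shown sit. With 3-methoxyphenyl in place of 2-methoxyphenyl, the series gives an at least 1.2-fold lower number from compound 3 to compound 4 (0.08 log units; that floor lies within the scatter). The changes from the bromo compounds give an at least 1.2-fold lower number from compound 2 to compound 4 (0.08 log units; that floor lies within the scatter) and an at least 1.2-fold lower number from compound 1 to compound 4 (0.08 log units; that floor lies within the scatter), so all three steps now have a floor, though none shows a gain beyond the scatter.

From the compounds shown here alone, the true size of these steps stays open, since each rests on a limit. Also open, going by these compounds, is whether an amine or a carboxylic acid on this aromatic ring would move the number beyond the scatter.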